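Removing One Methoxy Group from a Pyrazole Chalcone Series

The source may report more compounds than this note shows. Statements on the series, on what has been measured and on what is new or still open speak of the compounds shown alone.

The study concerns four pyrazole chalcones built on a shared core that carries an aryl group on one side and an aryl ketone on the other. Compound 1 `COc1ccc(-c2cc(/C=C/C(=O)c3ccc(N)cc3)[nH]n2)cc1` and compound 2 `COc1ccc(-c2cc(/C=C/C(=O)c3ccc(N)cc3)[nH]n2)cc1OC` differ only in one place: hydrogen in place of methoxy on an aromatic carbon. In a functional assay on U-251 cells (Homo sapiens) for inhibition, read by sulforhodamine B assay, with a stated time of 48 h (on this read-out higher numbers stand for weaker inhibition of growth and lower numbers for stronger inhibition of growth), compound 2 gives 1740 nM, while compound 1 gives 1240 nM, so the step is a 1.4-fold lower number from compound 2 to compound 1 (0.15 log units; within the scatter).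

Compound 3 `COc1cc(C(=O)/C=C/c2cc(-c3cc(OC)c(OC)c(OC)c3)n[nH]2)cc(OC)c1OC` carries the same kind of change toward compound 4 `COc1ccc(-c2cc(/C=C/C(=O)c3cc(OC)c(OC)c(OC)c3)[nH]n2)cc1OC`, namely (hydrogen in place of methoxy on an aromatic carbon). Around the place the two changes are not identical: in the change from compound 3 to compound 4 the carbon that loses its methoxy group is also meta to a methoxy group, which is not the case in the change from compound 2 to compound 1, so the two are the same kind of change rather than the same change. How the core of compound 3 differs from the core of compound 2 is not broken down here. In this assay, among the compounds with values here, compound 3 gives "not determined" (no result reported), so no step from compound 3 to compound 4 can be computed.

Within the data shown here, the expectation for compound 4 therefore rests on the only measured pair. Because a 1.4-fold lower number from compound 2 to compound 1 (0.15 log units; within the scatter) lay within the scatter, the step from compound 3 to compound 4 is expected to be of similarly small size, and the value of compound 4 is estimated near those of compound 1 and compound 2. Compound 4 is expected to give 1200 nM, with a plausible range from 300 nM to 5000 nM.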

Compound 4, concentration for 50% growth inhibition: 1240 nM
The estimate for compound 4 lay 1.0-fold (0.01 log units) below the measured number, and the stated range covers the measured number.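

In this assay, within the data shown here, compound 3 gives "not determined" (no result reported), so no step from it to compound 4 can be read. The compounds shown leave open how replacing the methoxy group with hydrogen acts on the core of compound 3, and whether it acts as it does between compound 2 and compound 1. Nothing available explains the value of compound 4.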